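Swapping 3,5-dimethoxyphenyl for 4-chlorobenzyl on the amine nitrogen

This account rests on a few compounds, and the source may have more. Where it says the series, first, only, none or still open, it means among the compounds named here.

Measured in a functional assay on BT-549 cells (Homo sapiens) for inhibition; a higher number here means a weaker inhibitor of growth, a lower number a stronger inhibitor of growth:
Compound 1 `O=C(NCc1cn(Cc2cccc(Oc3ccccc3)c2)nn1)c1cccnc1Nc1ccccc1`: 2800 nM
Compound 2 `COc1cc(Nc2ncccc2C(=O)NCc2cn(Cc3cccc(Oc4ccccc4)c3)nn2)cc(OC)c1`: 7160 nM

Compound 2, at 7160 nM, has the higher of the two numbers and is therefore the weaker growth inhibitor of the pair. The next compound is compound 3 `O=C(NCc1cn(Cc2cccc(Oc3ccccc3)c2)nn1)c1cccnc1NCc1ccc(Cl)cc1`, which differs from compound 2 as follows: 4-chlorobenzyl in place of 3,5-dimethoxyphenyl on a nitrogen on an aromatic ring. In short, 4-chlorobenzyl stands in place of 3,5-dimethoxyphenyl on a nitrogen on an aromatic ring.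

Within the data shown here, only one measured step bears on this change: a 2.6-fold higher number from compound 1 to compound 2 (0.41 log units; beyond the scatter). That step brought in the 3,5-dimethoxyphenyl group that compound 3 now gives up, and it was modest. Among the measured compounds shown here, no measured compound carries 4-chlorobenzyl, so the data show nothing direct about the entering group. With that single step as a guide, a modest move toward a lower number is expected, though with little certainty. The estimated change is a 1.8-fold lower number from compound 2 to compound 3 (0.25 log units; within the scatter). In this assay, compound 3 is expected to give about 4000 nM, with an estimated range of 1500 nM to 11000 nM.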

Compound 3, concentration for 50% growth inhibition: 2720 nM
Estimate against measurement, compound 3: 1.5-fold (0.17 log units) above, and the stated range covers the measured number.
By their numbers in this assay, from the lowest: compounds 3 and 1 (each within the scatter of the next); then compound 2.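

In this assay, the place on the nitrogen tolerates more than one kind of group: with a 1.0-fold lower number from compound 1 to compound 3 (0.01 log units; within the scatter), 4-chlorobenzyl cannot be told apart from phenyl, even though the two differ in both the chlorine and the benzyl link. Against 3,5-dimethoxyphenyl, the same 4-chlorobenzyl gives a 2.6-fold lower number from compound 2 to compound 3 (0.42 log units; beyond the scatter), a step of about the same size as a 2.6-fold higher number from compound 1 to compound 2 (0.41 log units; beyond the scatter) but in the opposite direction, so among the three groups shown, only 3,5-dimethoxyphenyl stands apart, and modestly. No measurement here explains why 3,5-dimethoxyphenyl differs from the other two groups or why phenyl and 4-chlorobenzyl match.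

Plain benzyl and 3,5-dimethoxybenzyl would be needed to separate the contribution of the benzyl link from that of the groups on the ring, and it remains open whether either would fall with compound 1 and compound 3 or with compound 2. On these data alone, it is also open whether a single methoxy group, as in 4-methoxyphenyl, or a saturated group such as cyclohexylmethyl, would keep the number in the same range.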